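A smaller ring on the sulfonyl sulfur of compound 2

The source may hold more compounds than are shown below. What is called first, only, known or untested is meant among the compounds shown, and "the series" means these compounds.

Measured so far in a toxicity assay on HepG2 cells (Homo sapiens) for cytotoxicity, read by MTT assay, with a stated time of 48 h; a lower number here means that less compound is tolerated, a higher number that more compound is tolerated:
Compound 1 `CN1CCN(S(=O)(=O)c2ccc(-c3ccc4cnnc(Nc5ccc(OCc6cccc(F)c6)c(Cl)c5)c4c3)cc2)CC1` gives > 5 uM
Compound 2 `CN1CCCN(S(=O)(=O)c2ccc(-c3ccc4ccnc(Nc5ccc(OCc6cccc(F)c6)c(Cl)c5)c4c3)cc2)CC1` gives > 15 uM

Compound 2 stands at > 15 uM and this is a limit of the assay, not a number. Compound 1 stands at > 5 uM and this too is only a limit. Neither compound gives a figure, so no order between the two can be read.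

Compound 3 `CN1CCN(S(=O)(=O)c2ccc(-c3ccc4ccnc(Nc5ccc(OCc6cccc(F)c6)c(Cl)c5)c4c3)cc2)CC1` differs from compound 2 in one place: 4-methylpiperazin-1-yl in place of 4-methyl-1,4-diazepan-1-yl on a sulfonyl sulfur. Here 4-methylpiperazin-1-yl stands in place of 4-methyl-1,4-diazepan-1-yl on a sulfonyl sulfur. Among the compounds with values here, no measured pair shows what such a change does in this assay, so no step beyond the usual scatter is expected, in either direction. This expectation rests on compound 2 and its limit of > 15 uM alone. The estimated change is a number no higher from compound 2 to compound 3 (the limit leaves the size open) and it stays within the scatter. Compound 3 is estimated at 15 uM with an expected range from 6 uM to 30 uM.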

Compound 3, half-maximal toxic concentration: > 15 uM
Compound 3 ended at the assay's limit; the forecaster's own chance of this, stated with the estimate: 70%; the middle value sits exactly at the limit.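

In this assay compound 3 gives > 15 uM, which is a limit of the assay and not a number. Compound 2 gives > 15 uM, also a limit, so no step from compound 2 to compound 3 can be read; both stop at the same point: the limit of > 15 uM in this assay, at which 2 of the 3 values shown sit.

The compounds shown leave open whether 4-methylpiperazin-1-yl and 4-methyl-1,4-diazepan-1-yl on a sulfonyl sulfur differ at all in how much compound is tolerated.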